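Fluoro for Methyl: Expecting Little Movement in Maximal Response

The source may report more compounds than this note shows. Statements on the series, on what has been measured and on what is new or still open speak of the compounds shown alone.

This account follows a single structural step within a small set of amide-linked sulfonamides examined in a functional assay on HEK293 cells for agonist activity at probable G-protein coupled receptor 27 (Homo sapiens), read by a luciferase reporter and beta-arrestin recruitment, with a stated time of 10 min; on this read-out higher numbers stand for larger maximal responses and lower numbers for smaller maximal responses. Two members of the set carry no number. Compound 1 `O=C(Nc1ccc(S(=O)(=O)NCc2ccccc2)cc1)c1ccc(Cl)cc1Cl` is recorded as "not determined" (no result reported). Compound 2 `COc1ccc(NS(=O)(=O)c2ccc(NC(=O)c3ccc(Cl)cc3Cl)cc2)cc1` likewise stands at "not determined" (no result reported). The whole set therefore rests on one measured compound. Compound 3 `Cc1cc(Cl)ccc1C(=O)Nc1ccc(S(=O)(=O)Nc2ccccc2)cc1` reaches 123% in this assay, and with the other two entries empty it is simply the only number shown, neither high nor low relative to any companion.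

Compound 4 `O=C(Nc1ccc(S(=O)(=O)Nc2ccccc2)cc1)c1ccc(Cl)cc1F` has not been measured. It differs from compound 3 in one place: fluoro in place of methyl on an aromatic carbon. For the measured compounds named here, since no pair of measured compounds differs in one place, no measured step exists to guide the size of this change. The exchange of one heavy atom for another of the same count, with no change in ring, donors, acceptors or charge, gives no reason in the data to expect a step beyond the usual scatter in this assay, in either direction.

Compound 4 is accordingly expected to give 115%, with a range from 80% to 150%. The expected step of a number 8 percentage points lower from compound 3 to compound 4 (within the scatter) is estimated to remain within the ordinary spread of repeated measurements.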

Compound 4, largest response reached (Emax), in percent of the reference or control that the assay uses: 57%
For compound 4 the middle estimate is 58 percentage points above the measured one; measured number below the stated range.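

In this assay the exchange of methyl for fluoro, on an aromatic carbon ortho to a large group and meta to a chloro group, gives a number 66 percentage points lower from compound 3 to compound 4 (beyond the scatter) and so clearly separates the 4-chloro-2-methylphenyl form from the 4-chloro-2-fluorophenyl form. For the compounds shown here, as the only measured step in the set, it shows that the maximal response is sensitive at this position to the identity of a single heavy atom, even though the exchange leaves the counts of rings, hydrogen-bond donors and hydrogen-bond acceptors and the net charge unchanged. The information available offers no explanation for the size or direction of this step.

With only methyl and fluoro compared at this position, the compounds shown cannot tell whether the step reflects the departure of methyl or the arrival of fluoro, a question that a hydrogen, a methoxy group or an amine in the same place could help to settle. Steps involving compound 1 and compound 2 cannot be read, so it also remains open whether the same exchange would have a similar effect on any other core.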